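The compounds below may be only part of what the source reports. "The series", "measured", "known", "first", "only" and "open" are said of these compounds alone.

Measured so far in a functional assay (aorta) for inhibition, with Rattus norvegicus as the target, with a stated time of 8 days; a lower number here means a stronger inhibitor, a higher number a weaker inhibitor:
- compound 1 `Cc1nsc(-c2ccc(N3CCN(c4cccc(C(F)(F)F)c4)CC3)nn2)n1`: 0.3 nM
- compound 2 `Cc1nsc(-c2ccc(N3CCN(c4cccc(C#N)c4)CC3)nn2)n1`: 3 nM

Compound 1 holds the lower of the two numbers. Compound 3 `Cc1nsc(-c2ccc(N3CCN(c4cc(C(F)(F)F)cc(C(F)(F)F)c4)CC3)nn2)n1` departs from it by trifluoromethyl in place of hydrogen on an aromatic carbon, which is trifluoromethyl in place of hydrogen on an aromatic carbon. For the measured compounds named here, only one measured step bears on this, a 10-fold higher number from compound 1 to compound 2 (1.00 log units; beyond the scatter), and it swaps the existing trifluoromethyl rather than adding a group, so it shows sensitivity to substitution on this ring but gives no direction for the new change. A small move is expected, and the estimated step is a 2.0-fold higher number from compound 1 to compound 3 (0.30 log units; within the scatter). For compound 3 the expected value is 0.6 nM, with an estimated range of 0.1 nM to 4 nM.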

Compound 3, half-maximal inhibitory concentration: < 0.1 nM
Compound 3: a limit, no number; the forecaster's own chance of this, stated with the estimate: 3%; middle value at least 6.0-fold (0.77 log units) from the limit.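

In this assay, trifluoromethyl in place of hydrogen on an aromatic carbon, meta to a trifluoromethyl group, gives an at least 3.0-fold lower number from compound 1 to compound 3 (0.47 log units; beyond the scatter). This position therefore accepts an added group with a gain, whereas the earlier pair showed only a swap of the existing trifluoromethyl. The value of compound 3 is a limit and not a number, so the step carries only a bound: the limit of < 0.1 nM in this assay, at which 1 of the 3 values shown sits.

Going by these compounds, whether this gain is specific to trifluoromethyl remains open, as an amine, a carboxylic acid or a methoxy group at this position could behave differently. Also open, on these data alone, is the effect of this trifluoromethyl when the existing one is replaced by hydrogen.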